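The source may report more compounds than this note shows. Statements on the series, on what has been measured and on what is new or still open speak of the compounds shown alone.

Measured so far:
compound 1 `O=C(Nc1cccc(-n2cc(-c3ccncc3)c(-c3ccc(Cl)c(O)c3)n2)c1)Nc1ccc(Cl)c(Cl)c1` — > 32500 nM
compound 2 `COc1cc(-c2nn(-c3cccc(NC(=O)Nc4ccc(Cl)c(C(F)(F)F)c4)c3)cc2-c2ccncc2)ccc1Cl` — > 32500 nM
compound 3 `COc1cc(-c2nn(-c3cccc(NC(=O)c4ccccc4)c3)cc2-c2ccncc2)ccc1Cl` — 12300 nM

In a functional assay on MDA-MB-435 cells (Homo sapiens) for inhibition, read by sulforhodamine B assay, with a stated time of 48 h (a higher number here means that more compound is tolerated, a lower number that less compound is tolerated), compound 1 gives only a limit, > 32500 nM, not a number. Compound 2 likewise sits at a limit, > 32500 nM. Compound 3 gives a number, 12300 nM. Going by the values given here, the one step that differs in a single place, an at least 2.6-fold lower number from compound 2 to compound 3 (0.42 log units; beyond the scatter), swaps the whole substituted anilino group on the carbonyl carbon for phenyl and lowers the number by an at least modest amount. Compound 1 thus stands at the upper edge of what is shown, a position it shares with one other compound (the limit of > 32500 nM in this assay, at which 2 of the 3 values shown sit).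

Compound 4 `O=C(Nc1cccc(-n2cc(-c3ccncc3)c(-c3ccc(Cl)c(O)c3)n2)c1)Nc1cccc(C(F)(F)F)c1` differs from compound 1 by 3-(trifluoromethyl)phenyl in place of 3,4-dichlorophenyl on an amide-type nitrogen. Among the compounds with values here, no measured step changes only the substituents on that phenyl; the step from compound 2 to compound 3 bears on it only loosely, since it shows the urea of compound 2 tolerating more compound than the benzamide of compound 3, and compound 4 keeps the urea. Both ureas measured so far sit at the limit. Compound 4 is therefore expected to give 30000 nM (range 10000 nM to 65000 nM), a step of an at least 1.0-fold lower number from compound 1 to compound 4 (0.03 log units; that floor lies within the scatter) that is expected to stay within the scatter, and most likely again only a limit.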

Compound 4, concentration lethal to 50% of the cells: > 32500 nM
Compound 4 was reported as a limit; the forecaster's own chance of this, stated with the estimate: 65%; middle value at least 1.0-fold (0.03 log units) from the limit.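

Going by these compounds alone, compound 4, like compound 1, sits at a limit and not at a number, so no step between the two can be read: the limit of > 32500 nM in this assay, at which 3 of the 4 values shown sit. In this assay the compounds shown leave open whether 3-(trifluoromethyl)phenyl and 3,4-dichlorophenyl on the amide-type nitrogen differ at all.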